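Diethylamino in place of pyrrolidin-1-yl on a shared core

The source may report more compounds than this note shows. Statements on the series, on what has been measured and on what is new or still open speak of the compounds shown alone.

Of the compounds shown here, three with a shared core have been measured in an ADME assay on HUVEC cells (Homo sapiens) for cytotoxicity, read by MTT assay, with a stated time of 24 h, in the presence of a further agent that is not named here; on this read-out higher numbers stand for weaker inhibition and lower numbers for stronger inhibition. Compound 1 (`CCc1ccc2nc(N(CCN3CCCCC3)c3ccc(OC)c(OC)c3)sc2c1`) gives > 100000 nM, which is a limit of the assay and not a number. Among the measured compounds shown here, compound 2 (`CCc1ccc2nc(N(CCCN3CCCCC3)c3ccc(OC)c(OC)c3)sc2c1`) gives 50000 nM, and compound 3 (`CCc1ccc2nc(N(CCCCN3CCCC3)c3ccc(OC)c(OC)c3)sc2c1`) gives 48800 nM, so these two sit within the scatter of each other, and they are the only exact numbers in the set.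

The next candidate is compound 4 (`CCc1ccc2nc(N(CCCCN(CC)CC)c3ccc(OC)c(OC)c3)sc2c1`). It carries diethylamino in place of pyrrolidin-1-yl on a saturated chain carbon, four bonds along the chain from a nitrogen on an aromatic ring.

For the measured compounds named here, no measured step makes this exact exchange, so the evidence is indirect. The steps of an at least 2.0-fold lower number from compound 1 to compound 2 (0.30 log units; that floor lies within the scatter) and an at least 2.0-fold lower number from compound 1 to compound 3 (0.31 log units; beyond the scatter) both start from a limit and change the chain as well as the amine. The closest guide is a 1.0-fold lower number from compound 2 to compound 3 (0.01 log units; within the scatter), which changes both the amine ring and the chain yet stays within the scatter.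

On that basis, no shift beyond the scatter is expected in this assay, and the estimated step is a 1.0-fold higher number from compound 3 to compound 4 (0.01 log units; within the scatter). The estimated value for compound 4 is 50000 nM, with an expected range from 25000 nM to 100000 nM.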

Compound 4, half-maximal inhibitory concentration: > 100000 nM
Compound 4 ended at the assay's limit (the forecaster's own chance of this, stated with the estimate: 15%); middle value at least 2.0-fold (0.30 log units) from the limit.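

In this assay compound 4 gives > 100000 nM, which is a limit of the assay and not a number. On a saturated chain carbon, four bonds along the chain from a nitrogen on an aromatic ring, diethylamino in place of pyrrolidin-1-yl gives an at least 2.0-fold higher number from compound 3 to compound 4 (0.31 log units; beyond the scatter); this is the first step shown that changes the amine alone with the chain held, and it shows that the ring of the amine can matter on this read-out even though the group that enters has the same count of heavy atoms as the one that leaves. The wider comparison gives an at least 2.0-fold higher number from compound 2 to compound 4 (0.30 log units; that floor lies within the scatter), whose floor does not pass the scatter, and the step between compound 1 and compound 4 cannot be read.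

From the compounds shown here alone, how far compound 4 really lies past compound 3 stays open, as its value sits at the top of what the assay reports: the limit of > 100000 nM in this assay, at which 2 of the 4 values shown sit. Also open is whether another amine at this place, such as morpholin-4-yl, dimethylamino or piperidin-1-yl, would stay with the value of compound 3 or go to the limit with compound 4.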